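The compounds below may be only part of what the source reports. "The series", "measured", "known", "first", "only" and "open" are said of these compounds alone.

In a functional assay on cells (Homo sapiens) for inhibition (on this read-out higher numbers stand for weaker inhibition and lower numbers for stronger inhibition), compound 3 `O=C(/C=C\N(O)c1ccccc1)c1ccc(F)cc1` gives > 10000 nM, a limit of the assay and not a number. Compound 4 `CN(O)/C=C\C(=O)c1ccc(F)cc1` has methyl in place of phenyl on an amine nitrogen. Compound 1 `CN(O)/C=C\C(=O)c1ccc([N+](=O)[O-])cc1`, with methyl on that nitrogen, gives > 10000 nM, also a limit. Compound 2 `CN(O)/C=C\C(=O)c1ccc(Cl)cc1`, with methyl there too, gives > 10000 nM, again a limit. Going by the values given here, the only measured step, a step that the two limits leave unreadable from compound 1 to compound 2, has no readable size and changes an aromatic carbon, not the amine nitrogen. All the measurements share one limit: the limit of > 10000 nM in this assay, at which 3 of the 3 values shown sit. No step beyond the scatter is therefore expected in this assay, and the estimated step is a step that the limit leaves unreadable from compound 3 to compound 4. Compound 4 is expected near 12000 nM, within 4000 nM to 30000 nM.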

Compound 4, half-maximal inhibitory concentration: 5500 nM
For compound 4 the middle estimate is 2.2-fold (0.34 log units) above the measured one; low and high end bracket the measured number.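

Going by these compounds alone, compound 4 is the first compound here to give a number rather than a limit in this assay, so this pairing of methyl on the amine nitrogen with fluoro on the aromatic carbon can be placed on the scale. Methyl in place of phenyl gives an at least 1.8-fold lower number from compound 3 to compound 4 (0.25 log units; that floor lies within the scatter), fluoro in place of chloro gives an at least 1.8-fold lower number from compound 2 to compound 4 (0.25 log units; that floor lies within the scatter), and fluoro in place of nitro gives an at least 1.8-fold lower number from compound 1 to compound 4 (0.25 log units; that floor lies within the scatter). Each step is only a floor, and its true size stays unknown: the limit of > 10000 nM in this assay, at which 3 of the 4 values shown sit.

Still open, from the compounds shown here alone, is how an ethyl group or a longer chain on the amine nitrogen, or a methoxy group on the aromatic carbon, would read out.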